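Anilino series: from compound 3 to compound 4

The compounds below may be only part of what the source reports. "The series", "measured", "known", "first", "only" and "open" are said of these compounds alone.

Values in a functional assay on HeLa cells (Homo sapiens) for inhibition, read by sulforhodamine B assay; on this read-out lower numbers stand for stronger inhibition and higher numbers for weaker inhibition:
- compound 1 `CCc1ccc(NC2=CC(=O)c3nc4n(c3C2=O)[C@H]2OC[C@@H](O)[C@H]2OC4)cc1`: 3990 nM
- compound 2 `CCOc1ccccc1NC1=CC(=O)c2nc3n(c2C1=O)[C@H]1OC[C@@H](O)[C@H]1OC3`: 6040 nM
- compound 3 `O=C1C=C(Nc2ccccc2)C(=O)c2c1nc1n2[C@H]2OC[C@@H](O)[C@H]2OC1`: 5620 nM

Compound 3, at 5620 nM, cannot be separated from the other two: the numbers show a 1.4-fold higher number from compound 1 to compound 3 (0.15 log units; within the scatter) and a 1.1-fold lower number from compound 2 to compound 3 (0.03 log units; within the scatter). Compound 4 `O=C1C=C(Nc2ccc(I)cc2)C(=O)c2c1nc1n2[C@H]2OC[C@@H](O)[C@H]2OC1` carries iodo in place of hydrogen on an aromatic carbon, para to a large group (iodo in place of hydrogen on an aromatic carbon). The closest evidence is compound 1, a 4-ethylphenyl compound, through a 1.4-fold higher number from compound 1 to compound 3 (0.15 log units; within the scatter). Compound 2 adds a 1.1-fold lower number from compound 2 to compound 3 (0.03 log units; within the scatter). As far as these compounds go, neither step lies beyond the scatter, although iodo itself is untested, so no step beyond the scatter is expected in this assay. The expected change is a 1.2-fold lower number from compound 3 to compound 4 (0.10 log units; within the scatter). For compound 4 the estimate is 4500 nM, with an expected range of 1900 nM to 8500 nM.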

Compound 4, half-maximal inhibitory concentration: 4070 nM
Estimate against measurement, compound 4: 1.1-fold (0.04 log units) above; low and high end bracket the measured number.
By their numbers in this assay, from the lowest: compounds 1, 4, 3 and 2 (each within the scatter of the next).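

In this assay, iodo on the aromatic carbon para to a large group cannot be separated from hydrogen (a 1.4-fold lower number from compound 3 to compound 4 (0.14 log units; within the scatter)) or from ethyl at that carbon (a 1.0-fold higher number from compound 1 to compound 4 (0.01 log units; within the scatter)). The 4-iodophenyl group on the amine nitrogen likewise cannot be separated from 2-ethoxyphenyl (a 1.5-fold lower number from compound 2 to compound 4 (0.17 log units; within the scatter)), so this single heavy atom adds a third substituted anilino compound with no step beyond the scatter. No measured evidence bears on the reason for this result. Still open, as far as these compounds go, is whether a carboxylic acid, an amine or a longer chain at this carbon would give a step beyond the scatter.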